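The source may hold more compounds than are shown below. What is called first, only, known or untested is meant among the compounds shown, and "the series" means these compounds.

The measured compounds:
Compound 1, `C/C(C#Cc1ccccc1)=N\N/C(N)=N/S(=O)(=O)c1cc(C)c(Cl)cc1SCc1ccc(C)cc1`: in an ADME assay on HaCaT cells (Homo sapiens) for cytotoxicity, read by MTT assay, with a stated time of 72 h (a lower number here means a stronger inhibitor, a higher number a weaker inhibitor), compound 1 gives 270000 nM.
Compound 2, `C/C(C#Cc1ccccc1)=N\N/C(N)=N/S(=O)(=O)c1cc(C)c(Cl)cc1SCc1ccc(C(F)(F)F)cc1`: in this assay compound 2 gives 120000 nM.
Compound 3, `C/C(C#Cc1ccccc1)=N\N/C(N)=N/S(=O)(=O)c1cc(C)c(Cl)cc1SCc1ccccc1Cl`: in this assay compound 3 gives 340000 nM.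

Compound 3 carries the highest of the three numbers. The step of a 1.3-fold higher number from compound 1 to compound 3 (0.10 log units; within the scatter) lies within the scatter, so the two values cannot be ordered; the step of a 2.8-fold higher number from compound 2 to compound 3 (0.45 log units; beyond the scatter) lies beyond the scatter and is modest. Compound 4, `C/C(C#Cc1ccccc1)=N\N/C(N)=N/S(=O)(=O)c1cc(C)c(Cl)cc1SCc1ccc(Cl)cc1`, differs from compound 3 by 4-chlorophenyl in place of 2-chlorophenyl on a saturated chain carbon bound to a sulfur. Both measured steps that end in compound 3 alter the same place, the aryl on the saturated chain carbon bound to a sulfur. Of these, one was within the scatter and one modest, and in both the entering group carried its substituent at the ring's 4-position, as the 4-chlorophenyl of compound 4 does. Among the compounds with values here, no step of this kind has moved the number by more than a modest amount, and no step ever raised it beyond the scatter. Compound 4 is therefore expected to show at most a small lowering, a 1.5-fold lower number from compound 3 to compound 4 (0.17 log units; within the scatter), in this assay. Compound 4 is estimated at 230000 nM, with a range from 110000 nM to 450000 nM.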

Compound 4, half-maximal inhibitory concentration: 16000 nM
The estimate for compound 4 lay 14-fold (1.16 log units) above the measured number; measured number below the stated range.
By their numbers in this assay, from the lowest: compound 4; then compound 2; then compounds 1 and 3 (each within the scatter of the next).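

In this assay, the exchange of 2-chlorophenyl for 4-chlorophenyl on a saturated chain carbon bound to a sulfur gives a 21-fold lower number from compound 3 to compound 4 (1.33 log units; beyond the scatter), so at this position the same atoms joined differently produce a large step, whereas the earlier changes here stayed modest or within the scatter. The substituent on the ring also counts, since chloro in place of trifluoromethyl gives a 7.5-fold lower number from compound 2 to compound 4 (0.88 log units; beyond the scatter) and chloro in place of methyl gives a 17-fold lower number from compound 1 to compound 4 (1.23 log units; beyond the scatter), so 4-methylphenyl and 4-(trifluoromethyl)phenyl do not predict what 4-chlorophenyl does. Nothing measured here explains this result. From the compounds shown here alone, whether bromo, methoxy or an amine in place of the chloro of compound 4 would keep the number as low stays open. So does whether the same exchange of 2-chlorophenyl for 4-chlorophenyl would give a step of this size on another core.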